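A few compounds are considered here, and "the series" means these few. Any claim that something is new, unique, unknown or untested is made for them only; others in the source may bear on it.

Working notes on the oxazole-carboxamide piperazine series in a functional assay on HL-60 cells (Homo sapiens) for inhibition, read by MTT assay, with a stated time of 72 h; a lower number here means a stronger inhibitor, a higher number a weaker inhibitor. Compound 1 `Cc1nc(-c2ccc(F)cc2)c(C(=O)N2CCN(c3ccc(C(=O)C(C)C)cc3)CC2)o1` carries a 4-fluorophenyl group on the shared core and a 4-isobutyrylphenyl group on the piperazine; in this assay compound 1 gives "not active" (no number reported), and no number was reported for it. For the measured compounds named here, compound 2 `Cc1nc(-c2ccccc2)c(C(=O)N2CCN(c3ccc(Cl)c(Cl)c3)CC2)o1` carries an unsubstituted phenyl on the core and a 3,4-dichlorophenyl on the piperazine; in this assay compound 2 gives 124 nM, the only measured number in the set, so no comparison is possible yet.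

Compound 3 `Cc1nc(-c2ccccc2)c(C(=O)N2CCN(c3cccc(C)c3C)CC2)o1` keeps the core and phenyl of compound 2 and differs only at the piperazine nitrogen: 2,3-dimethylphenyl in place of 3,4-dichlorophenyl on an amine nitrogen in a ring. Going by the values given here, no measured pair differing in one place exists here, so the size of this step is unknown from the data. Among the compounds with values here, with only one number in hand, the expectation for the step from compound 2 to compound 3 is a moderate loss, estimated as a 3.2-fold higher number from compound 2 to compound 3 (0.51 log units; beyond the scatter). For compound 3 the estimate in this assay is 400 nM, with a range from 100 nM to 2000 nM.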

Compound 3, half-maximal inhibitory concentration: 35 nM
The estimate for compound 3 lay 11-fold (1.06 log units) above the measured number, outside the stated range (below it).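

In this assay, the aryl group on the amine nitrogen in a ring can change without losing activity: 2,3-dimethylphenyl in place of 3,4-dichlorophenyl gives a 3.5-fold lower number from compound 2 to compound 3 (0.55 log units; beyond the scatter). For the compounds shown here, this is the first readable step, and it shows that the two chlorine atoms of compound 2 are not needed for a nanomolar number at this place, since compound 3 has none and still improves on compound 2 by a modest step beyond the scatter. The two groups match in heavy-atom count, in ring type and in their lack of hydrogen-bond donors and acceptors, and no independent evidence here accounts for the difference in activity.

On these data alone, with only these two aryl groups compared, it remains open whether each methyl group contributes, or whether methoxy groups, a single methyl group or a trifluoromethyl group would serve as well at this place. Compound 1 differs from both measured compounds in more than one place, so it leaves open what a 4-fluorophenyl group on the shared core does on its own.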